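Cyano for methoxy on the anilino ring of compound 3

The compounds below may be only part of what the source reports. "The series", "measured", "known", "first", "only" and "open" are said of these compounds alone.

Compound 3, `CCC/C=C/C(=O)Nc1cccc(Oc2nc(Nc3cccc(OC)c3)nc3ccsc23)c1`, stands on a limit in an ADME assay on L02 cells (Homo sapiens) for inhibition, read by MTT assay, with a stated time of 72 h; a higher number here means a weaker inhibitor, a lower number a stronger inhibitor: compound 3 gives > 50000 nM, which is a limit of the assay and not a number. Compound 2, `CC/C=C/C(=O)Nc1cccc(Oc2nc(Nc3cccc(OC)c3)nc3ccsc23)c1`, likewise sits at a limit; in this assay compound 2 gives > 50000 nM. Compound 1, `COc1cccc(Nc2nc(Oc3cccc(NC(=O)C=C(C)C)c3)c3sccc3n2)c1`, has no result in this assay, its entry reading "not determined" (no result reported). Within the data shown here, the one measured step, a step that the two limits leave unreadable from compound 2 to compound 3, is therefore unreadable, because both of its ends rest on (the limit of > 50000 nM in this assay, at which 2 of the 3 values shown sit).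

Compound 4, `CCC/C=C/C(=O)Nc1cccc(Oc2nc(Nc3cccc(C#N)c3)nc3ccsc23)c1`, differs from compound 3 by cyano in place of methoxy on an aromatic carbon, a cyano in place of methoxy on an aromatic carbon, meta to a large group. No measured step touches this part of the shared core, so nothing among the shown values speaks for a shift in either direction. Compound 4 is expected to remain at the limit in this assay, and its estimate is 60000 nM, with a range from 20000 nM to 200000 nM. The step that the limit leaves unreadable from compound 3 to compound 4 is thus expected to be none beyond the scatter.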

Compound 4, half-maximal inhibitory concentration: > 50000 nM
Compound 4: only a limit was reported; the forecaster's own chance of this, stated with the estimate: 70%; the middle value is on the limit's open side.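

Compound 3 and compound 4 both rest on a limit and not on a number in this assay, so no step between them can be read: the limit of > 50000 nM in this assay, at which 3 of the 4 values shown sit.

The compounds shown leave open how cyano and methoxy on this aromatic carbon compare in this assay.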